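Replacing the fluorinated chain of compound 3 with an aryl ether

The source may report more compounds than this note shows. Statements on the series, on what has been measured and on what is new or still open speak of the compounds shown alone.

Values so far in a functional assay on the whole organism (strain ICR) for inhibition, with Mus musculus as the target, with a stated time of 16 h, at a dose of 10 mg/kg by the oral route; a higher number here means more inhibition at the dose given (going by the name of the read-out), a lower number less inhibition:
compound 1 `CCSCCC12CCC(c3nnc(-c4ccccc4C(F)(F)F)n3C)(CC1)CC2` gives 72%
compound 2 `Cn1c(-c2ccccc2C(F)(F)F)nnc1C12CCC(CNS(C)(=O)=O)(CC1)CC2` gives 27%
compound 3 `Cn1c(-c2ccccc2C(F)(F)F)nnc1C12CCC(CCCC(C)(F)F)(CC1)CC2` gives 94%

Compound 3 stands highest of the three in this assay; compound 1 is nearest to it and compound 2 furthest, both gaps beyond the scatter. The step under consideration leads to compound 4 `Cn1c(-c2ccccc2C(F)(F)F)nnc1C12CCC(COc3ccc(S(C)(=O)=O)cc3)(CC1)CC2`. The change is a group of 11 heavy atoms (7 carbon, 3 oxygen, 1 sulfur; one six-membered aromatic ring of carbon only) in place of a group of 6 heavy atoms (4 carbon, 2 fluorine; no ring), on a saturated chain carbon bound to a saturated ring carbon.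

Among the measured compounds shown here, two measured steps bear on this position. a number 67 percentage points higher from compound 2 to compound 3 (beyond the scatter). a number 22 percentage points higher from compound 1 to compound 3 (beyond the scatter). Both show that the group on the saturated chain carbon bound to the saturated ring carbon moves the read-out strongly, and that the group of compound 2, which contains sulfur and oxygen without carbon-bound fluorine, sits at the low end of the series. For the measured compounds named here, the entering group of compound 4 likewise contains sulfur and oxygen, though within a larger group carrying an aromatic ring, for which no measured step exists in this set. The direction therefore rests on compound 2 alone, with considerable uncertainty about size. A fall beyond the scatter from compound 3 is expected, a number 44 percentage points lower from compound 3 to compound 4 (beyond the scatter). Compound 4 is estimated at 50%, in the range 20% to 82%.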

Compound 4, a percentage reported as inhibition, in the whole organism at one dose (the size of the read-out at that dose, not a potency): 28%
Beside the measured number, compound 4's estimate is 22 percentage points above it; the measured number falls inside the stated range.
By their numbers in this assay, from the lowest: compounds 2 and 4 (each within the scatter of the next); then compound 1; then compound 3.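

Replacing the group of 6 heavy atoms (4 carbon, 2 fluorine) with 4-(methylsulfonyl)phenoxy on the saturated chain carbon bound to a saturated ring carbon gives, in this assay, a number 66 percentage points lower from compound 3 to compound 4 (beyond the scatter), so a group with an aromatic ring also falls to the low end of the series. Set against methanesulfonamido, the same group gives a number 1 percentage points higher from compound 2 to compound 4 (within the scatter), which places two differently built groups that both carry a methylsulfonyl unit level with each other; the added aromatic ring and the larger size bring no gain at this dose. Set against (ethylsulfanyl)methyl, it gives a number 44 percentage points lower from compound 1 to compound 4 (beyond the scatter), so across these four compounds the low values go with the methylsulfonyl unit, while the sulfur of compound 1 on its own does not go with them.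

Nothing available explains why the read-out falls with these groups. Plain phenoxy on the same carbon would show whether the aromatic ether or the methylsulfonyl unit goes with the low value, and a saturated chain ending in methylsulfonyl would test the same question without the ring.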